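The compounds below may be only part of what the source reports. "The series", "measured", "known", "first", "only" and "open" are said of these compounds alone.

Measured so far in a functional assay, tested at 100 uM; a lower number here means a weaker effect, a higher number a stronger effect of the compound at the concentration tested:
compound 1, `O=C(O)c1cn(Cc2ccc(Cl)cc2)c2ccccc2c1=O`: 28.7%
compound 2, `COc1ccc(Cn2cc(C(=O)O)c(=O)c3ccccc32)cc1OC`: 32.2%
compound 3, `O=C(NO)c1cn(Cc2ccc(Cl)cc2)c2ccccc2c1=O`: 31.7%

Compound 3 differs from compound 1 in one place, (hydroxyamino in place of hydroxy on a carbonyl carbon). The step that this change made was a number 3 percentage points higher from compound 1 to compound 3 (within the scatter), so the two values lie within the usual scatter of each other. Compound 2 differs from compound 1 in more than one place; the difference between the two cores is not broken down here. In this assay compound 2 and compound 3 also lie within the scatter of each other.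

Compound 4, `COc1ccc(Cn2cc(C(=O)NO)c(=O)c3ccccc32)cc1OC`, has not yet been measured. It differs from compound 2 by hydroxyamino in place of hydroxy on a carbonyl carbon, the same change, at the same kind of place, as from compound 1 to compound 3. The step is expected to be small, a number 1.8 percentage points higher from compound 2 to compound 4 (within the scatter), because the earlier step was a number 3 percentage points higher from compound 1 to compound 3 (within the scatter). Compound 4 is therefore estimated at 34%, expected to fall between 24% and 44%.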

Compound 4, a percentage reported as activity, at one concentration (the size of the read-out at that concentration, not a potency): 39.1%
Beside the measured number, compound 4's estimate is 5.1 percentage points below it; measured number inside the range.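

In this assay, putting hydroxyamino in place of hydroxy on the carbonyl carbon of compound 2 gives a number 6.9 percentage points higher from compound 2 to compound 4 (within the scatter). Set beside the earlier step, the change shows no difference between the two cores: the same change on two cores in this assay, a number 3 percentage points higher (within the scatter) from compound 1 to compound 3 and a number 6.9 percentage points higher (within the scatter) from compound 2 to compound 4, 3.9 percentage points apart, within the scatter of two such steps. This does not show that the change raises the read-out on either core, as each step on its own lies within the scatter, and two cores are too few to establish a rule for the series.

The compounds shown leave open what other groups on that carbonyl carbon, such as a simple amide or a methyl ester, would do. They also leave open whether the change would read the same at another concentration.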